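Fluoro Added to a Methyl-Bearing Quinolinone Benzimidazole

A few compounds are considered here, and "the series" means these few. Any claim that something is new, unique, unknown or untested is made for them only; others in the source may bear on it.

Compound 1 `COc1ccc2[nH]c(=O)c(-c3nc4cc(F)ccc4[nH]3)cc2c1` in a functional assay on SK-OV-3 cells (Homo sapiens) for cytotoxicity, read by MTT assay, with a stated time of 48 h (a lower number here means a stronger inhibitor, a higher number a weaker inhibitor), gives > 100000 nM, a limit of the assay.
Compound 2 `O=c1[nH]c2ccccc2cc1-c1nc2cc(F)ccc2[nH]1` in this assay gives 18300 nM.
Compound 3 `Cc1ccc2[nH]c(=O)c(-c3nc4ccccc4[nH]3)cc2c1` in this assay gives > 100000 nM, a limit of the assay.

Compound 3 stands at the limit, the position described by the limit of > 100000 nM in this assay, at which 2 of the 3 values shown sit. Compound 4 `Cc1ccc2[nH]c(=O)c(-c3nc4cc(F)ccc4[nH]3)cc2c1` differs from compound 3 by fluoro in place of hydrogen on an aromatic carbon. For the measured compounds named here, the only measured step, an at least 5.4-fold lower number from compound 1 to compound 2 (0.73 log units; beyond the scatter), concerns a methoxy rather than a fluoro and so does not bear directly on this change; no measured pair shows the effect of adding fluoro. Compound 2 carries the fluoro and lies off the limit, while compound 1 carries it and does not. Compound 4 is therefore expected to remain weak, with an at least 1.2-fold lower number from compound 3 to compound 4 (0.09 log units; that floor lies within the scatter); the estimate for compound 4 is 80000 nM, within 20000 nM to 300000 nM.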

Compound 4, half-maximal inhibitory concentration: > 100000 nM
Compound 4 was reported as a limit (the forecaster's own chance of this, stated with the estimate: 60%); middle value at least 1.2-fold (0.09 log units) from the limit.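

For the compounds shown here, a methyl group taking the place of the hydrogen gives an at least 5.4-fold higher number from compound 2 to compound 4 (0.73 log units; beyond the scatter) in this assay, the first readable step for methyl at this position on the fluoro-bearing core. Among the fluoro-bearing compounds, only compound 2, with hydrogen there, lies off the limit, while compound 1 with methoxy and compound 4 with methyl both sit at it. The limit now holds most of the compounds shown: the limit of > 100000 nM in this assay, at which 3 of the 4 values shown sit.

From the compounds shown here alone, the steps from compound 3 to compound 4 and from compound 1 to compound 4 join two limits and cannot be read, so the effect of fluoro remains unknown. Going by these compounds, whether an amine or a carboxylic acid at this position would give a value off the limit also stays open.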